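Replacing methyl with cyano in a high-solubility compound

The source may report more compounds than this note shows. Statements on the series, on what has been measured and on what is new or still open speak of the compounds shown alone.

Measured values in a physicochemical assay for solubility, in phosphate buffer, measured as kinetic solubility (a lower number here means a less soluble compound, a higher number a more soluble compound), are

Compound 1 `CCc1nn2c(-c3cc(OC)c(OC)cc3OC)cccc2c1N(CC1CCOCC1)CC1CC1` gives 3600 nM
Compound 2 `CCc1nn2c(-c3c(COC)cc(OC)cc3OC)cccc2c1N(CC1CCOCC1)CC1CC1` gives 2900 nM
Compound 3 `COCc1cc(OC)c(-c2cccc3c(N(CC4CCOCC4)CC4CC4)c(C)nn23)c(OC)c1` gives 21000 nM

Compound 3 has the highest number of the three, and its gaps to compound 1 and compound 2 both lie beyond the scatter. Compound 4 `COCc1cc(OC)c(-c2cccc3c(N(CC4CCOCC4)CC4CC4)c(C#N)nn23)c(OC)c1` has cyano in place of methyl on an aromatic carbon. For the measured compounds named here, no measured pair differs in one place only, so nothing here sizes this change directly. The high value of compound 3 (21000 nM) leaves room to fall, which makes a drop the loose expectation. A moderate drop in this assay is expected, only just beyond the scatter (a 2.3-fold lower number from compound 3 to compound 4 (0.37 log units; beyond the scatter)). The estimate for compound 4 is 9000 nM (expected range 3000 nM to 27000 nM).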

Compound 4, solubility: 1700 nM
For compound 4 the middle estimate is 5.3-fold (0.72 log units) above the measured one; the measured number lies below the stated range.
By their numbers in this assay, from the lowest: compounds 4, 2 and 1 (each within the scatter of the next, the first and the last beyond it); then compound 3.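

For the compounds shown here, this is the first comparison in the set where only one place changes. In this assay, cyano in place of methyl on the aromatic carbon next to the ring nitrogen gives a 12-fold lower number from compound 3 to compound 4 (1.09 log units; beyond the scatter) and counts as a large step, so this read-out is sensitive to the group at this position. Nothing measured here explains why.

From the compounds shown here alone, it remains open whether an amide or a longer chain at this position would land nearer compound 3 or compound 4. Going by these compounds, it is also open whether the same swap would give a step of similar size with the other substitution patterns on the trimethoxyphenyl-type group.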